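Benzoxazole sulfonamides: cytotoxicity notes on a small series

The source may hold more compounds than are shown below. What is called first, only, known or untested is meant among the compounds shown, and "the series" means these compounds.

Measured so far:
Compound 1 `O=S(=O)(Nc1ccc2oc(-c3ccccc3)nc2c1)c1cccc(C(F)(F)F)c1`: in an ADME assay on HEK293 cells (Homo sapiens) for cytotoxicity, read by resazurin assay, with a stated time of 48 h (on this read-out lower numbers stand for higher toxicity in this test and higher numbers for lower toxicity in this test), compound 1 reaches only a limit of the assay, > 100000 nM.
Compound 2 `COc1cccc(S(=O)(=O)Nc2ccc3oc(-c4ccccc4)nc3c2)c1`: in this assay compound 2 gives 63000 nM.
Compound 3 `O=S(=O)(Nc1ccc(-c2nc3ccccc3o2)cc1)c1ccc(C(F)(F)F)cc1`: in this assay compound 3 gives 94000 nM.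

The step of an at least 1.5-fold lower number from compound 1 to compound 2 (0.20 log units; that floor lies within the scatter) rests on the change (methoxy in place of trifluoromethyl on an aromatic carbon). Its starting point is a limit (the limit of > 100000 nM in this assay, at which 1 of the 3 values shown sits), so only a floor of the step is known, and that floor lies within the scatter. Compound 3 and compound 1 hold the same atoms joined differently; the difference between the two cores is not broken down here. Compound 3 and compound 2 lie within the scatter of each other.

Compound 4 `COc1ccc(S(=O)(=O)Nc2ccc(-c3nc4ccccc4o3)cc2)cc1` is not yet measured. It differs from compound 3 by methoxy in place of trifluoromethyl on an aromatic carbon. This is the same kind of change as from compound 1 to compound 2, not the same: there the methoxy sits meta to a large group, here para to a large group.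

In this assay a step of a 1.6-fold lower number from compound 3 to compound 4 (0.19 log units; within the scatter) is expected. It rests on the step of an at least 1.5-fold lower number from compound 1 to compound 2 (0.20 log units; that floor lies within the scatter), of which only a floor within the scatter is known, so a small downward step with wide uncertainty is assumed. Compound 4 is estimated at 60000 nM, between 25000 nM and 150000 nM.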

Compound 4, half-maximal cytotoxic concentration: > 100000 nM
Compound 4: only a limit was reported; the forecaster's own chance of this, stated with the estimate: 25%; at least 1.6-fold (0.22 log units) between middle value and limit.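

In this assay the change from trifluoromethyl to methoxy gives an at least 1.0-fold higher number from compound 3 to compound 4 (0.02 log units; that floor lies within the scatter); compound 4 reaches only a limit of the assay, so this step is known only as a floor. Set beside the earlier step, this result neither shows that the change carries over from one core to the other nor shows that it fails to do so: the same change on two cores in this assay, an at least 1.5-fold lower number (0.20 log units; that floor lies within the scatter) from compound 1 to compound 2 and an at least 1.0-fold higher number (0.02 log units; that floor lies within the scatter) from compound 3 to compound 4; the limit leaves it open whether they differ. As far as these compounds go, neither floor lies beyond the scatter, and the true size of each step remains unknown, so no size or direction can be assigned to this change across the series: the limit of > 100000 nM in this assay, at which 2 of the 4 values shown sit.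

Still open, from the compounds shown here alone, is whether an amine or a carboxylic acid in place of trifluoromethyl, on the same aromatic carbon, would give numbers rather than limits on both cores, and so allow a direct comparison. A nitrile or a longer alkoxy chain at that place would raise the same question, and the compounds shown give no indication of the outcome.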